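Sugar-bearing triazole on a liver cell toxicity read-out

The source may hold more compounds than are shown below. What is called first, only, known or untested is meant among the compounds shown, and "the series" means these compounds.

Of the compounds shown here, three sharing one core have been measured in a toxicity assay on L02 cells (Homo sapiens) for cytotoxicity, read by MTT assay, with a stated time of 72 h; on this read-out higher numbers stand for weaker inhibition and lower numbers for stronger inhibition. Compound 1 `O=C1c2c[n+]([O-])c3ccccc3c2C(=O)c2c1c1ccccc1n2Cc1cn(C[C@@H](O)CO)nn1` gives 490 nM. Compound 2 `O=C1c2c[n+]([O-])c3ccccc3c2C(=O)c2c1c1ccccc1n2Cc1cn(CC(O)CO)nn1` gives 1070 nM, and compound 3 `O=C1c2c[n+]([O-])c3ccccc3c2C(=O)c2c1c1ccccc1n2CCCCN1CCCCC1` gives 610 nM. Compound 2 thus holds the highest of the three numbers; its nearest neighbour is compound 3 and its furthest is compound 1. The step of a 2.2-fold higher number from compound 1 to compound 2 (0.34 log units; beyond the scatter) is the only one beyond the scatter, and it rests on (the fact that one of compounds 1 and 2 is drawn with a defined configuration and the other without, at the place where they differ). The two other steps, a 1.2-fold higher number from compound 1 to compound 3 (0.10 log units; within the scatter) and a 1.8-fold lower number from compound 2 to compound 3 (0.24 log units; within the scatter), exchange the whole 1-(2,3-dihydroxypropyl)-1H-1,2,3-triazol-4-yl group for 3-(piperidin-1-yl)propyl and both stay within the scatter.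

Compound 4 `O=C1c2c[n+]([O-])c3ccccc3c2C(=O)c2c1c1ccccc1n2Cc1cn([C@@H]2O[C@H](CO)[C@@H](O)[C@H](O)[C@H]2O)nn1` has not yet been measured. It differs from compound 2 in one place: 3,4,5-trihydroxy-6-(hydroxymethyl)oxan-2-yl in place of 2,3-dihydroxypropyl on an aromatic nitrogen. Going by the values given here, no measured step alters the group on that aromatic nitrogen itself; the closest comparisons, a 1.2-fold higher number from compound 1 to compound 3 (0.10 log units; within the scatter) and a 1.8-fold lower number from compound 2 to compound 3 (0.24 log units; within the scatter), remove the group altogether with little effect, so in this assay the step of a 1.1-fold higher number from compound 2 to compound 4 (0.05 log units; within the scatter) is expected to remain within the scatter. Compound 4 is therefore estimated at 1200 nM, with a range from 500 nM to 2900 nM.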

Compound 4, half-maximal inhibitory concentration: 420 nM
Compound 4: the middle estimate sits 2.9-fold (0.46 log units) above what was measured; the whole stated range lies above it.
By their numbers in this assay, from the lowest: compounds 4, 1, 3 and 2 (each within the scatter of the next, the first and the last beyond it).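

Going by these compounds alone, the aromatic nitrogen of the five-membered ring, a place no earlier step had altered directly, takes the 3,4,5-trihydroxy-6-(hydroxymethyl)oxan-2-yl group, with 11 heavy atoms and a six-membered non-aromatic ring in place of the 5 heavy atoms of the open 2,3-dihydroxypropyl, and in this assay the number does not rise beyond the scatter against either dihydroxypropyl compound. Within the data shown here, the exchange gives a 2.5-fold lower number from compound 2 to compound 4 (0.41 log units; beyond the scatter), the first change at this place to go beyond the scatter, but also a 1.2-fold lower number from compound 1 to compound 4 (0.07 log units; within the scatter), so the size of its effect depends on which dihydroxypropyl compound serves as the reference. Those two references are separated by one thing only: the fact that one of compounds 1 and 2 is drawn with a defined configuration and the other without, at the place where they differ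

The compounds shown leave open whether the ring of the sugar, its number of hydroxyl groups or the configuration of its stereocentres matters, since a single sugar carries all of these at once. They also leave open how this place would respond to a group of another kind on the same nitrogen, such as an amine, a carboxylic acid or a longer alkyl chain.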